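A short-lived compound gains an amino side chain

The compounds below may be only part of what the source reports. "The series", "measured", "known", "first", "only" and "open" are said of these compounds alone.

Compound 1 (`CCc1nc(-c2ccc(Cl)cc2Cl)c(CC)nc1CC(CC)CC`): 0.0417 h
Compound 2 (`CCc1nc(-c2ccc(Cl)cc2Cl)c(OC)nc1NC(CC)CC`): 0.183 h

In an in vitro ADME assay on microsomes (Rattus norvegicus) for metabolic stability (a higher number here means that the compound lasts longer, a lower number that the compound disappears faster), compound 1 stands lowest of the two numbers at 0.0417 h and compound 2 stands at 0.183 h, a gap that lies beyond the scatter, even though the two differ in more than one place. For the measured compounds named here, no measured pair isolates a single change, so any forecast here is uncertain.

The next molecule is compound 3 (`CCCN(CC1CC1)c1nc(CC)c(-c2ccc(Cl)cc2Cl)nc1CC`), in which (cyclopropylmethyl)(propyl)amino takes the place of 2-ethylbutyl on an aromatic carbon ((cyclopropylmethyl)(propyl)amino in place of 2-ethylbutyl on an aromatic carbon). The rest of compound 1 stays the same.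

With compound 2 at 0.183 h as the only higher reference, a small rise or none beyond the scatter is expected in this assay for this change. The estimated step of a 1.7-fold higher number from compound 1 to compound 3 (0.22 log units; within the scatter) is therefore modest and upward. For compound 3 the expected half-life is 0.07 h with an estimated range of 0.03 h to 0.17 h at this stage.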

Compound 3, half-life: 0.07 h
Beside the measured number, compound 3's estimate shows no gap at the digits printed; the measured number falls inside the stated range.
By their numbers in this assay, from the lowest: compounds 1 and 3 (each within the scatter of the next); then compound 2.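

In this assay, for the compounds shown here, putting (cyclopropylmethyl)(propyl)amino in place of 2-ethylbutyl on this aromatic carbon gives a 1.7-fold higher number from compound 1 to compound 3 (0.22 log units; within the scatter), the first comparison here that isolates a single change. At this position, then, a side chain joined through nitrogen and carrying a three-membered ring gives a half-life that cannot be told apart from that of the all-carbon 2-ethylbutyl chain. Nothing available explains this result.

As far as these compounds go, it remains open whether another group on this carbon, such as a morpholine ring or a chain ending in a carboxylic acid, would move the half-life beyond the scatter. Also open, from the compounds shown here alone, is whether placing a methoxy group in place of one ethyl group on the shared core would, as a single change, shift the number at all.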